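This account rests on a few compounds, and the source may have more. Where it says the series, first, only, none or still open, it means among the compounds named here.

Measured so far in an assay on membranes from CHO cells for displacement of a labelled ligand from adenosine receptor A1 (Homo sapiens), read by scintillation counting, with a stated time of 60 min, tested at 1 uM; on this read-out lower numbers stand for less inhibition and higher numbers for more inhibition at the one concentration tested (going by the name of the read-out):
- compound 1 `CC(=O)C1=C(C)NC(=O)NC1c1ccsc1`: 9%
- compound 2 `CCNC(=O)C1=C(C)NC(=O)NC1c1ccsc1`: 3%
- compound 3 `CC1=C(c2ncc(C)o2)C(c2ccco2)NC(=O)N1`: 27%

Compound 3 stands highest of these three numbers, beyond the scatter above both compound 1 and compound 2. Compound 4 `CC1=C(c2ncc(C)o2)C(c2ccsc2)NC(=O)N1` differs from compound 3 by thiophen-3-yl in place of furan-2-yl on a saturated ring carbon. For the measured compounds named here, no measured step exchanges these two rings. Going by the values given here, the only measured step, a number 6 percentage points lower from compound 1 to compound 2 (within the scatter), alters a different group and lies within the scatter, so it gives no guidance here. Compound 1 and compound 2 also bear thiophen-3-yl, yet they differ from compound 3 in other places as well, so their low numbers are only a weak hint. The expected step of a number 5 percentage points lower from compound 3 to compound 4 (within the scatter) is therefore small, possibly downward but not clearly beyond the scatter. Compound 4 is estimated at 22%, between 8% and 40%.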

Compound 4, a percentage reported as inhibition, at one concentration (the size of the read-out at that concentration, not a potency): 34%
Compound 4: middle estimate off by 12 percentage points, on the low side; measured number inside the range.
By their numbers in this assay, from the lowest: compounds 2 and 1 (each within the scatter of the next); then compounds 3 and 4 (each within the scatter of the next).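

In this assay the exchange of furan-2-yl for thiophen-3-yl on the saturated ring carbon gives a number 7 percentage points higher from compound 3 to compound 4 (within the scatter), so these two rings cannot be told apart at this position. With thiophen-3-yl kept, 5-methyl-1,3-oxazol-2-yl on the double-bonded ring carbon gives a number 31 percentage points higher from compound 2 to compound 4 (beyond the scatter) against ethylcarbamoyl and a number 25 percentage points higher from compound 1 to compound 4 (beyond the scatter) against acetyl, so among these compounds the larger differences follow that carbon's group. Nothing available explains these numbers. Still open, as far as these compounds go, is how a phenyl or pyridin-3-yl ring would read on the saturated ring carbon. From the compounds shown here alone, a carboxylic acid or an ester in place of 5-methyl-1,3-oxazol-2-yl is equally open.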